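A few compounds are considered here, and "the series" means these few. Any claim that something is new, unique, unknown or untested is made for them only; others in the source may bear on it.

Three compounds sharing one core were compared in a functional assay on MCF7 cells (Homo sapiens) for antiproliferative activity, read by MTT assay, with a stated time of 72 h; a higher number here means a weaker inhibitor, a lower number a stronger inhibitor. Compound 1 `COc1cc(-n2cnc3ccc(-c4ccccc4Cl)cc32)cc(OC)c1OC` gives > 10000 nM in this assay, which is a limit of the assay rather than a number. Compound 2 `COc1cc(-n2cnc3ccc(-c4cc(F)ccc4F)cc32)cc(OC)c1OC` gives 6420 nM in this assay, and compound 3 `COc1cc(-n2cnc3ccc(-c4cccc(C)c4)cc32)cc(OC)c1OC` gives 360 nM in this assay. The step of an at least 1.5-fold lower number from compound 1 to compound 2 (0.19 log units; that floor lies within the scatter) is small, whereas an at least 27-fold lower number from compound 1 to compound 3 (1.44 log units; beyond the scatter) and an 18-fold lower number from compound 2 to compound 3 (1.25 log units; beyond the scatter) are large. Compound 4 `COc1cc(-n2cnc3ccc(-c4cccc(C)c4C)cc32)cc(OC)c1OC` differs from compound 1 in one place: 2,3-dimethylphenyl in place of 2-chlorophenyl on an aromatic carbon. Because compound 1 sits at the limit of > 10000 nM in this assay, at which 1 of the 3 values shown sits, only a floor for any gain is known; the 3-methylphenyl of compound 3 is the nearest measured guide, and it brought an at least 27-fold lower number from compound 1 to compound 3 (1.44 log units; beyond the scatter), so a sizeable drop in this assay is expected, though compound 4 carries a second methyl that compound 3 lacks. Compound 4 is therefore expected to give 1500 nM in this assay, between 300 nM and 8000 nM. The expected step is an at least 6.6-fold lower number from compound 1 to compound 4 (0.82 log units; beyond the scatter).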

Compound 4, half-maximal inhibitory concentration: 2150 nM
Estimate against measurement, compound 4: 1.4-fold (0.16 log units) below; the range from low to high includes it.
By their numbers in this assay, from the lowest: compound 3; then compound 4; then compound 2. At a limit, above all of these: compound 1.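

In this assay, the added methyl on the phenyl ring gives a 6.0-fold higher number from compound 3 to compound 4 (0.78 log units; beyond the scatter), so the second methyl does not preserve the activity seen with the 3-methylphenyl group alone. The 2,3-dimethylphenyl group still compares favourably with the 2,5-difluorophenyl group, with a 3.0-fold lower number from compound 2 to compound 4 (0.48 log units; beyond the scatter). The step of an at least 4.6-fold lower number from compound 1 to compound 4 (0.66 log units; beyond the scatter) is only a floor, because the starting value is a limit of the assay: the limit of > 10000 nM in this assay, at which 1 of the 4 values shown sits.

The compounds shown leave open how a methoxy group, an amine or a carboxylic acid on this phenyl ring would fare in this assay.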